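The source may report more compounds than this note shows. Statements on the series, on what has been measured and on what is new or still open speak of the compounds shown alone.

Working notes on the series. Compound 2 `Cc1ccc(-c2cn3nc(Cc4ccc(Cl)cc4)sc3n2)cc1` stands in a functional assay on L1210 cells (Mus musculus) for cytotoxicity, with a stated time of 48 h (a lower number here means a stronger inhibitor, a higher number a weaker inhibitor), at a limit of the assay, reported as > 250000 nM, which is a limit and not a number. Compound 1 `Clc1ccc(Cc2nn3cc(-c4ccc(Br)cc4)nc3s2)cc1` likewise sits at a limit in this assay, giving > 250000 nM. For the measured compounds named here, the one measured step between them, a step that the two limits leave unreadable from compound 1 to compound 2, cannot be read because of the limit of > 250000 nM in this assay, at which 2 of the 2 values shown sit. Compound 3 `Clc1ccc(Cc2nn3cc(-c4ccccc4)nc3s2)cc1` differs from compound 2 by hydrogen in place of methyl on an aromatic carbon. Going by the values given here, no measured step bears directly on this change; the only step available, methyl in place of bromo, is itself unreadable, so neither a size nor a direction for this assay can be drawn from it, and nothing in the two readings shows potency appearing anywhere. The change to compound 3 is a small one, and the expectation is that it remains at the same limit. The expected step is therefore a number no higher from compound 2 to compound 3 (the limit leaves the size open), that is, none beyond the scatter. Compound 3 is estimated at 250000 nM, in a range from 80000 nM to 1000000 nM, most probably reported again only as a limit.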

Compound 3, half-maximal inhibitory concentration: > 250000 nM
Compound 3: no number, only a limit (the forecaster's own chance of this, stated with the estimate: 85%); the middle value lies on the limit itself.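

No new step can be read among compound 1, compound 2 and compound 3, because all three give only a limit and no number in this assay: the limit of > 250000 nM in this assay, at which 3 of the 3 values shown sit.

The compounds shown leave open whether bromo, methyl and hydrogen on this aromatic carbon differ at all, and whether any change to the shared core gives a measurable value in this assay.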